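Thiourea triazole series: cytotoxicity notes on a para bromo analogue

A few compounds are considered here, and "the series" means these few. Any claim that something is new, unique, unknown or untested is made for them only; others in the source may bear on it.

Measured compounds:
compound 1 `S=C(Nc1ccc(Cl)c(Cl)c1)Nc1nc[nH]n1` — 47000 nM
compound 2 `Cc1ccc(NC(=S)Nc2nc[nH]n2)cc1` — 59000 nM
compound 3 `S=C(Nc1cccc(Br)c1)Nc1nc[nH]n1` — 50000 nM

In an ADME assay on MT4 cells (Homo sapiens) for cytotoxicity, read by MTT assay, with a stated time of 96 h (a higher number here means that more compound is tolerated, a lower number that less compound is tolerated), compound 1 gives 47000 nM, compound 2 gives 59000 nM and compound 3 gives 50000 nM. On these three numbers compound 2 stands together with compound 1 and compound 3: the gap from compound 2 to compound 3 and the gap from compound 2 to compound 1 are both within the scatter, so none of the three can be told apart in this assay. No pair of these compounds differs in a single place, so no single-point step has been measured within the set.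

Compound 4 `S=C(Nc1ccc(Br)cc1)Nc1nc[nH]n1` is the next analogue. Compared with compound 2 the change is bromo in place of methyl on an aromatic carbon, on an aromatic carbon of a six-membered aromatic ring of carbon only, para to a group of nine heavy atoms. With compound 3, which carries bromo on the same type of ring, giving 50000 nM and compound 2 giving 59000 nM, no step beyond the scatter is expected here. Compound 4 is therefore estimated at 50000 nM, within 25000 nM to 100000 nM, and the expected step is a 1.2-fold lower number from compound 2 to compound 4 (0.07 log units; within the scatter).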

Compound 4, half-maximal cytotoxic concentration: > 100000 nM
Compound 4 was reported as a limit; the forecaster's own chance of this, stated with the estimate: 10%; middle value at least 2.0-fold (0.30 log units) from the limit.
By their numbers in this assay, from the lowest: compounds 1, 3 and 2 (each within the scatter of the next). At a limit, above all of these: compound 4.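

In this assay compound 4 is reported only as a limit, > 100000 nM. This gives the series its first step in a single place, an at least 1.6-fold higher number from compound 2 to compound 4 (0.22 log units; that floor lies within the scatter), and shows that bromo in place of methyl on an aromatic carbon, para to a group of 9 heavy atoms, brings no lower number at this position, although the floor of the step alone does not separate the two compounds. The true size of the step cannot be fixed, because the reading ends at a limit: the limit of > 100000 nM in this assay, at which 1 of the 4 values shown sits.

Where the value of compound 4 really lies remains open, and so does whether the tolerance belongs to bromo alone or extends to other groups at this place. An amine or a carboxylic acid on the same aromatic carbon would test that second question.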